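The compounds below may be only part of what the source reports. "The series", "measured", "known", "first", "only" and "open" are said of these compounds alone.

Compound 1 `CC(C)(C)C1=NN(c2ccc(Br)cc2)C(c2ccc(O)cc2)C1` gives 93.2% in an assay on isolated protein for inhibition of protein kinase C zeta type (Homo sapiens), with a stated time of 4 min, tested at 62.5 uM; a lower number here means less inhibition, a higher number more inhibition at the concentration tested (going by the name of the read-out).
Compound 2 `CC(C)c1ccc(N2N=C(C(C)(C)C)CC2c2ccc(O)cc2)cc1` gives 54.9% in this assay.
Compound 3 `CC(C)(C)C1=NN(c2cccc(F)c2)C(c2ccc(O)cc2)C1` gives 98.1% in this assay.

Among these three numbers compound 1 stands second highest. Its nearest neighbour is compound 3, and the step of a number 4.9 percentage points higher from compound 1 to compound 3 (within the scatter) lies within the usual scatter, so the two cannot be told apart. Its furthest neighbour is compound 2, reached by the step of a number 38.3 percentage points lower from compound 1 to compound 2 (beyond the scatter), a change of isopropyl in place of bromo on an aromatic carbon that clearly lowered inhibition.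

Compound 4 `Cc1cccc(N2N=C(C(C)(C)C)CC2c2ccc(O)cc2)c1` is not yet measured. It differs from compound 1 in one place: 3-methylphenyl in place of 4-bromophenyl on an amine nitrogen in a ring. For the measured compounds named here, the step that bears most directly on this change is the one to compound 3, where a different ring was also put on the ring nitrogen and the number moved only a number 4.9 percentage points higher from compound 1 to compound 3 (within the scatter). The large drop to compound 2 came from a change elsewhere in the molecule and is a weaker guide here. On that basis the expected step for compound 4 is a number 3.2 percentage points lower from compound 1 to compound 4 (within the scatter), within the scatter. Compound 4 is therefore estimated at 90%, with a likely range from 72% to 99%.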

Compound 4, a percentage reported as inhibition, at one concentration (the size of the read-out at that concentration, not a potency): 91.7%
The estimate for compound 4 lay 1.7 percentage points below the measured number, and the stated range covers the measured number.
By their numbers in this assay, from the lowest: compound 2; then compounds 4, 1 and 3 (each within the scatter of the next).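

In this assay, a second change of the ring on the amine nitrogen gives a number 1.5 percentage points lower from compound 1 to compound 4 (within the scatter), so 3-methylphenyl and 4-bromophenyl cannot be told apart here. Methyl in place of fluoro on an aromatic carbon gives a number 6.4 percentage points lower from compound 3 to compound 4 (within the scatter), which is also too small to separate the two groups. Compounds 1, 3 and 4 therefore sit together with bromo, fluoro or methyl on this ring, while compound 2 goes against this pattern, with isopropyl giving a number 38.3 percentage points lower from compound 1 to compound 2 (beyond the scatter).

As far as these compounds go, it remains open whether this ring would also keep the number with a carboxylic acid or an amine on it, or whether such groups would lower it as isopropyl did. Nothing shown here explains why bromo, fluoro and methyl give such similar numbers or why isopropyl differs.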